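Adding a hydroxy group to the ring of compound 3

This account rests on a few compounds, and the source may have more. Where it says the series, first, only, none or still open, it means among the compounds named here.

In a functional assay on HepG2 cells (Homo sapiens) for antiproliferative activity, read by MTT assay, with a stated time of 72 h (a lower number here means a stronger inhibitor, a higher number a weaker inhibitor), compound 1 `COc1cc2c(Nc3ccc(C#N)cc3)ncnc2cc1OCCCN(C)C` reaches only a limit, > 100000 nM. Compound 2 `COc1cc2c(Nc3ccc(C#N)cc3)ncnc2cc1OCCCN1CCCC1` gives 20900 nM, and compound 3 `COc1cc2c(Nc3ccc(C#N)cc3)ncnc2cc1OCCCN1CCCCC1` gives 20700 nM, level with compound 2. Replacing dimethylamino with pyrrolidin-1-yl gives an at least 4.7-fold lower number from compound 1 to compound 2 (0.67 log units; beyond the scatter), and replacing it with piperidin-1-yl gives an at least 4.8-fold lower number from compound 1 to compound 3 (0.68 log units; beyond the scatter). Exchanging those two rings gives a 1.0-fold lower number from compound 2 to compound 3 (0.00 log units; within the scatter), within the scatter. Compound 4 `COc1cc2c(Nc3ccc(C#N)cc3)ncnc2cc1OCCCN1CCC(O)CC1` carries hydroxy in place of hydrogen on a saturated ring carbon. Going by the values given here, no measured step adds a hydroxy group, so the closest guide is the ring exchange, a 1.0-fold lower number from compound 2 to compound 3 (0.00 log units; within the scatter), which left the number unmoved. The expected step is a 1.4-fold higher number from compound 3 to compound 4 (0.13 log units; within the scatter), no change beyond the scatter. The estimate for compound 4 is 28000 nM, within an expected range of 10000 nM to 80000 nM.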

Compound 4, half-maximal inhibitory concentration: 67900 nM
Estimate against measurement, compound 4: 2.4-fold (0.38 log units) below; the range from low to high includes it.
By their numbers in this assay, from the lowest: compounds 3 and 2 (each within the scatter of the next); then compound 4. At a limit, above all of these: compound 1.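

In this assay, exchanging the two rings gives a 1.0-fold lower number from compound 2 to compound 3 (0.00 log units; within the scatter), but one hydroxy on a saturated ring carbon, three ring bonds from the ring nitrogen, gives a 3.3-fold higher number from compound 3 to compound 4 (0.52 log units; beyond the scatter). The same weakening appears against the pyrrolidine analogue, a 3.2-fold higher number from compound 2 to compound 4 (0.51 log units; beyond the scatter), so this far ring carbon does not tolerate every change. The step from the dimethylamino analogue is only a floor, an at least 1.4-fold lower number from compound 1 to compound 4 (0.16 log units; that floor lies within the scatter). Compound 1 stands at a limit: the limit of > 100000 nM in this assay, at which 1 of the 4 values shown sits.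

Going by these compounds, whether the loss belongs to hydroxy alone stays open. A methoxy group, an amine or a carboxylic acid on that same ring carbon would test it.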